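From Trifluorobenzyl to Indazolylmethyl on a Shared Core

The source may hold more compounds than are shown below. What is called first, only, known or untested is meant among the compounds shown, and "the series" means these compounds.

In a functional assay on A-375 cells (Homo sapiens) for antiproliferative activity (on this read-out higher numbers stand for weaker inhibition and lower numbers for stronger inhibition), compound 1 `O=C(Nc1ccc(-c2cscn2)cc1)C1CCCN(C(=O)c2ccc(F)c(F)c2)C1` gives > 20000 nM, which is a limit of the assay. For the measured compounds named here, compound 2 `O=C(Nc1ccc(-c2cscn2)cc1)C1CCCN(Cc2cccc(F)c2F)C1` gives 1480 nM, and compound 3 `O=C(Nc1ccc(-c2cscn2)cc1)C1CCCN(Cc2cc(F)c(F)c(F)c2)C1` gives 400 nM, the lowest number so far. Replacing the (3,4-difluorophenyl)carbonyl group with a benzyl group produced large steps, an at least 13-fold lower number from compound 1 to compound 2 (1.13 log units; beyond the scatter) and an at least 50-fold lower number from compound 1 to compound 3 (1.69 log units; beyond the scatter). Compound 4 `O=C(Nc1ccc(-c2cscn2)cc1)C1CCCN(Cc2ccc3cn[nH]c3c2)C1` keeps the methylene link and changes the aromatic group: 1H-indazol-6-yl in place of 3,4,5-trifluorophenyl on a saturated chain carbon bound to an amine nitrogen in a ring. Going by the values given here, the closest precedent is the modest aryl change a 3.7-fold lower number from compound 2 to compound 3 (0.57 log units; beyond the scatter), whereas the larger steps concern a different change. A modest rise in this assay is therefore expected, with an estimated 2.0-fold higher number from compound 3 to compound 4 (0.30 log units; within the scatter). Compound 4 is estimated at 800 nM, with an expected range of 200 nM to 3500 nM.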

Compound 4, half-maximal inhibitory concentration: > 20000 nM
Compound 4: no number, only a limit (the forecaster's own chance of this, stated with the estimate: 7%); middle value at least 25-fold (1.39 log units) from the limit.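

Keeping the methylene link does not by itself keep the activity in this assay: the aromatic group on the saturated chain carbon bound to an amine nitrogen in a ring decides the outcome, as an at least 50-fold higher number from compound 3 to compound 4 (1.69 log units; beyond the scatter) and an at least 13-fold higher number from compound 2 to compound 4 (1.13 log units; beyond the scatter) show. The result for compound 4 is a limit, not a number. The step from compound 1 to compound 4 cannot be read: the limit of > 20000 nM in this assay, at which 2 of the 4 values shown sit.

The compounds shown leave open whether the loss follows the five-membered aromatic ring of 1H-indazol-6-yl as a whole or its ring hydrogen alone. They also leave open how a benzyl group carrying an amine or a carboxylic acid would fare at this place.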